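Capping the piperidine nitrogen with a hydroxyacetyl group

The compounds below may be only part of what the source reports. "The series", "measured", "known", "first", "only" and "open" are said of these compounds alone.

Two compounds share a common core and differ only in the ring attached to an aromatic nitrogen. Compound 1 `CN1CCN(c2ccc(Nc3ncc4nc(Nc5ccc(F)cc5)n([C@@H]5CCN(C(=O)CO)C5)c4n3)cc2)CC1` carries a pyrrolidine bearing a (hydroxymethyl)carbonyl group; in a functional assay on HCC827 cells (Homo sapiens) for antiproliferative activity, read by MTT assay, with a stated time of 72 h (on this read-out lower numbers stand for stronger inhibition and higher numbers for weaker inhibition), compound 1 gives 350 nM. Among the compounds with values here, compound 2 `CN1CCN(c2ccc(Nc3ncc4nc(Nc5ccc(F)cc5)n([C@@H]5CCCNC5)c4n3)cc2)CC1` carries a piperidine with a free amine nitrogen, and in this assay compound 2 gives 120 nM, the lower of the two numbers measured so far. The measured step of a 2.9-fold lower number from compound 1 to compound 2 (0.46 log units; beyond the scatter) combined a change of ring size with removal of the acyl group, so it bears only indirectly on the new change. Compound 3 `CN1CCN(c2ccc(Nc3ncc4nc(Nc5ccc(F)cc5)n([C@@H]5CCCN(C(=O)CO)C5)c4n3)cc2)CC1` is compound 2 with (hydroxymethyl)carbonyl in place of hydrogen on an amine nitrogen in a ring. Within the data shown here, a modest rise in the number is expected for compound 3, of about a 2.1-fold higher number from compound 2 to compound 3 (0.32 log units; beyond the scatter), because the only comparable step a 2.9-fold lower number from compound 1 to compound 2 (0.46 log units; beyond the scatter) moved the other way when the acyl group was removed. Compound 3 is therefore estimated at 250 nM, within a range of 100 nM to 600 nM.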

Compound 3, half-maximal inhibitory concentration: 66 nM
Beside the measured number, compound 3's estimate is 3.8-fold (0.58 log units) above it, and the stated range ends above it.
By their numbers in this assay, from the lowest: compounds 3 and 2 (each within the scatter of the next); then compound 1.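

In this assay, putting (hydroxymethyl)carbonyl in place of hydrogen on the amine nitrogen of the six-membered ring gives a 1.8-fold lower number from compound 2 to compound 3 (0.26 log units; within the scatter), so in this pair the nitrogen can carry the acyl group or stay free with no difference that can be told from the scatter. With that acyl group present in both compounds, the step from the 1-((hydroxymethyl)carbonyl)pyrrolidin-3-yl group to the 1-((hydroxymethyl)carbonyl)piperidin-3-yl group gives a 5.3-fold lower number from compound 1 to compound 3 (0.72 log units; beyond the scatter), which singles out ring size as a change that registers beyond the scatter. Nothing measured here explains either step.

The compounds shown leave open how a plain acetyl group, lacking the hydroxyl, or a simple methyl group would fare on this nitrogen. From the compounds shown here alone, a longer hydroxyalkyl chain or a carboxylic acid at the same place also remains untested.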